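Urea compounds stabilising a kinase against heat

The source may report more compounds than this note shows. Statements on the series, on what has been measured and on what is new or still open speak of the compounds shown alone.

Measured so far:
Compound 1, `CC(C)(C)c1cc(NC(=O)Nc2cc(F)cc(F)c2)n(-c2ccccc2)n1`: 3 degrees C
Compound 2, `CC(C)(C)c1cc(NC(=O)Nc2ccc(Cl)cc2)n(-c2ccc(C(F)(F)F)cc2)n1`: 0.7 degrees C

Both compounds were tested in an assay on isolated protein for inhibition of STE20-like serine/threonine-protein kinase (Homo sapiens), read by thermal shift assay, tested at 10 uM; on this read-out lower numbers stand for weaker stabilisation of the target and higher numbers for stronger stabilisation of the target against heat. Compound 1 gives 3 degrees C, while compound 2 gives 0.7 degrees C, which is the lower of the two numbers, and the gap between them lies beyond the usual scatter. The two compounds differ in more than one place, so no single change can be held responsible for that gap.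

Compound 3, `CC(C)C(=O)Nc1ccc(-n2nc(C(C)(C)C)cc2NC(=O)Nc2ccc(Cl)cc2)cc1`, has not yet been measured. It differs from compound 2 in one place: (isopropylcarbonyl)amino in place of trifluoromethyl on an aromatic carbon. In words, an (isopropylcarbonyl)amino group takes the place of the trifluoromethyl group on an aromatic carbon of a six-membered aromatic ring of carbon only, para to a large group.

Among the measured compounds shown here, no measured pair shows what such a change does in this assay. The expected step from compound 2 to compound 3 is therefore a number 0.80 degrees C higher from compound 2 to compound 3 (within the scatter), a modest move upward that may not clear the scatter. On that basis compound 3 is estimated to give 1.5 degrees C in this assay, with a range from -0.5 degrees C to 4 degrees C.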

Compound 3, shift of the target's melting temperature: 6.8 degrees C
Beside the measured number, compound 3's estimate is 5.3 degrees C below it; measured number outside the range, above it.
By their numbers in this assay, from the lowest: compound 2; then compound 1; then compound 3.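

In this assay, placing (isopropylcarbonyl)amino in place of trifluoromethyl on an aromatic carbon, para to a large group, gives a number 6.1 degrees C higher from compound 2 to compound 3 (beyond the scatter). Among the compounds shown here, this is the first change that can be read on its own, and it shows that this position strongly influences the read-out and accepts a larger group, with a hydrogen-bond donor, a hydrogen-bond acceptor and a double bond outside the aromatic rings, without any loss of stabilisation. Nothing available shows which feature of the new group accounts for the step, or how these compounds hold the protein.

The change alters several things at once, so the amide hydrogen, the carbonyl and the isopropyl part cannot yet be told apart; a plain amine, an acetylamino group or a carboxylic acid on the same aromatic carbon would help to separate their roles. Going by these compounds, it also remains open whether (isopropylcarbonyl)amino would have a similar effect on the core of compound 1, which carries a different group on the other side of the urea.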